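A few compounds are considered here, and "the series" means these few. Any claim that something is new, unique, unknown or untested is made for them only; others in the source may bear on it.

Compound 1, `CN(C)CC[C@H](CSc1ccccc1)Nc1ccc(S(=O)(=O)NC(=O)c2ccc(N3CCN(Cc4ccccc4-c4ccc(Cl)cc4)CC3)cc2)cc1OC(F)(F)F`, is the compound with the higher of the two numbers measured here. In a functional assay on NCI-H146 cells (Homo sapiens) for cytotoxicity, with a stated time of 48 h, in the presence of a further agent that is not named here (on this read-out lower numbers stand for an effect already at smaller amounts and higher numbers for an effect only at larger amounts of compound), compound 1 gives 5080 nM. Compound 2, `CN(C)CC[C@H](CSc1ccccc1)Nc1ccc(S(=O)(=O)NC(=O)c2ccc(N3CCN(CC4=C(c5ccc(Cl)cc5)CCC4)CC3)cc2)cc1[N+](=O)[O-]`, differs from it in more than one place and in this assay compound 2 gives 691 nM, a clearly lower number. Compound 3, `CN(C)CC[C@H](CSc1ccccc1)Nc1ccc(S(=O)(=O)NC(=O)c2ccc(N3CCN(Cc4ccccc4-c4ccc(Cl)cc4)CC3)cc2)cc1C#N`, differs from compound 1 in a single place: cyano in place of trifluoromethoxy on an aromatic carbon. Among the measured compounds shown here, no measured pair shows this exact change, so the size of the step is open. A modest move toward a lower number is expected rather than a change within the scatter. Compound 3 is estimated to give 2000 nM, between 600 nM and 6500 nM. The expected step is a 2.5-fold lower number from compound 1 to compound 3 (0.40 log units; beyond the scatter).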

Compound 3, half-maximal effective concentration: 1930 nM
Compound 3: the middle estimate sits 1.0-fold (0.02 log units) above what was measured; the measured number falls inside the stated range.
By their numbers in this assay, from the lowest: compound 2; then compound 3; then compound 1.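

This position on the aromatic ring, ortho to a large group and meta to a large group, responds to a single change: cyano in place of trifluoromethoxy gives a 2.6-fold lower number from compound 1 to compound 3 (0.42 log units; beyond the scatter) in this assay. The earlier compounds shown here differ in more than one place, so they could not show the effect of this position alone. As far as these compounds go, how an amine, a carboxylic acid or a plain hydrogen on this carbon would compare remains open, as does whether the step holds on other cores. Nothing measured here explains the step.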